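Carbamoylmethyl to 2-(dimethylamino)ethyl on the shared core

A few compounds are considered here, and "the series" means these few. Any claim that something is new, unique, unknown or untested is made for them only; others in the source may bear on it.

In a physicochemical assay for solubility, read by chemiluminescence, measured as kinetic solubility (a lower number here means a less soluble compound, a higher number a more soluble compound), compound 1 `COCCOc1nn(C)c2ncnc(NS(=O)(=O)c3cccc(Cl)c3Cl)c12` gives >= 463000 nM, which is a limit of the assay and not a number. Compound 2 `COc1nn(CC(N)=O)c2ncnc(NS(=O)(=O)c3cccc(Cl)c3Cl)c12` gives >= 490000 nM, which is also a limit. Going by the values given here, compound 2 therefore stands only at a limit, as does the one other value available, and no number orders the pair.

Compound 3 `COc1nn(CCN(C)C)c2ncnc(NS(=O)(=O)c3cccc(Cl)c3Cl)c12` differs from compound 2 in one place: (dimethylamino)methyl in place of carbamoyl on a saturated chain carbon bound to an aromatic nitrogen. (Dimethylamino)methyl stands in place of carbamoyl on a saturated chain carbon bound to an aromatic nitrogen.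

Among the compounds with values here, no measured step covers this change. As far as these compounds go, no step beyond the scatter is expected in this assay, and the direction stays open. The expected at least 1.1-fold lower number from compound 2 to compound 3 (0.06 log units; that floor lies within the scatter) is small. The expectation rests only on the limit for compound 2, >= 490000 nM. For compound 3 the estimate is 420000 nM, with an expected range of 180000 nM to 520000 nM.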

Compound 3, solubility: 358000 nM
Compound 3: the middle estimate sits 1.2-fold (0.07 log units) above what was measured; measured number inside the range.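

In this assay, going by these compounds alone, compound 3 gives the first reading of the series that is a number and not a limit, so this place, on a saturated chain carbon bound to an aromatic nitrogen, now has one firm value. The change from carbamoyl to (dimethylamino)methyl reads as an at least 1.3-fold lower number from compound 2 to compound 3 (0.13 log units; that floor lies within the scatter). This step is only a floor and its true size stays unread, as compound 2 stands at a limit: the limit of >= 490000 nM in this assay, at which 1 of the 3 values shown sits.

As far as these compounds go, how a carboxylic acid or a longer chain ending in an amine would read at this place stays open. Also open, from the compounds shown here alone, is whether carbamoylmethyl to 2-(dimethylamino)ethyl would read the same way on a compound carrying the other substituents of compound 1 on the shared core.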